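This account rests on a few compounds, and the source may have more. Where it says the series, first, only, none or still open, it means among the compounds named here.

Compound 1 `CCCCC(CCO)n1cnc2cncnc21`: > 50000 nM (a limit)
Compound 2 `CCCCCC(CCO)n1cnc2c(Cl)ncnc21`: > 50000 nM (a limit)
Compound 3 `CCCCCC(CCO)n1cnc2c(N(C)C)ncnc21`: > 50000 nM (a limit)

In a functional assay on SW480 cells (Homo sapiens) for antiproliferative activity, read by MTT assay, with a stated time of 48 h (on this read-out lower numbers stand for stronger inhibition and higher numbers for weaker inhibition), compound 3 gives > 50000 nM, which is a limit and not a number. Its place is the limit of > 50000 nM in this assay, at which 3 of the 3 values shown sit, so no ranking can be read from these results. Compound 4 `CCCCCC(CCO)n1cnc2cncnc21` carries hydrogen in place of dimethylamino on an aromatic carbon. For the measured compounds named here, the one measured step on an aromatic carbon is a step that the two limits leave unreadable from compound 2 to compound 3, and it offers no size to build on. With every measured value at the limit, no clear gain in inhibition is expected, and the estimated change is a step that the limit leaves unreadable from compound 3 to compound 4. The value expected for compound 4 is 60000 nM, with an estimated range from 30000 nM to 100000 nM.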

Compound 4, half-maximal inhibitory concentration: > 50000 nM
Compound 4 ended at the assay's limit; the forecaster's own chance of this, stated with the estimate: 85%; the middle value does not contradict the limit.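

Compound 4, like compound 1, compound 2 and compound 3, gives only a limit, so no step among these compounds can be read: the limit of > 50000 nM in this assay, at which 4 of the 4 values shown sit. The compounds shown leave open which change to the shared core, if any, would give a measurable value.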